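Trimming a Methyl from the Strongest Compound of Three

This account rests on a few compounds, and the source may have more. Where it says the series, first, only, none or still open, it means among the compounds named here.

Of the compounds shown here, three have been tested in a functional assay on the whole organism with Canis familiaris (Canis lupus familiaris) as the target, at a dose of 8 mg/kg by the oral route; a lower number here means a weaker effect, a higher number a stronger effect of the compound at the dose given. Compound 1 `Cc1cc(OCc2ccccc2)c2nc(C)c(C)n2c1` gives 71% and compound 2 `Cc1ccn2c(C)c(C)nc2c1OCc1ccccc1` gives 35%. Compound 3 `Cc1nc2c(OCc3ccccc3)cccn2c1N` gives 96%, the highest of the three numbers, beyond the scatter above compound 1 and further still above compound 2. Compound 4 `Nc1cnc2c(OCc3ccccc3)cccn12` has not yet been measured. It differs from compound 3 in one place: hydrogen in place of methyl on an aromatic carbon. Going by the values given here, no measured pair shows this change, so its size cannot be read from these numbers. Because compound 3 gives 96%, compound 4 is estimated near 85%, within a range from 60% to 98%. The expected step of a number 11 percentage points lower from compound 3 to compound 4 (beyond the scatter) is a small decrease, possibly none beyond the scatter.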

Compound 4, a percentage reported as inhibition, in the whole organism at one dose (the size of the read-out at that dose, not a potency): 43%
Compound 4: the middle estimate sits 42 percentage points above what was measured, outside the stated range (below it).
By their numbers in this assay, from the lowest: compounds 2 and 4 (each within the scatter of the next); then compound 1; then compound 3.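

Replacing the methyl on the aromatic carbon with hydrogen is no minor trim: in this assay it gives a number 53 percentage points lower from compound 3 to compound 4 (beyond the scatter). A single carbon atom at this place, on the five-membered aromatic ring and next to the ring atom that bears an amino group, is enough to separate the two compounds at this dose. Nothing available here explains why the effect falls so far. From the compounds shown here alone, whether an ethyl group or a chlorine atom on the same carbon would keep the effect seen with methyl remains open.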